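Swapping pyridin-2-yl for thiophen-2-yl

A few compounds are considered here, and "the series" means these few. Any claim that something is new, unique, unknown or untested is made for them only; others in the source may bear on it.

Compound 1 `O=C(Nc1ccc(-c2cscn2)cc1)C1CCCN(Cc2ccccc2F)C1` gives 7000 nM
Compound 2 `O=C(Nc1ccc(-c2cscn2)cc1)C1CCCN(Cc2ccc(Cl)c(Cl)c2)C1` gives 3000 nM
Compound 3 `O=C(Nc1ccc(-c2ccccn2)cc1)C1CCCN(Cc2ccc(F)c(F)c2)C1` gives 11000 nM

All three values come from a functional assay on A-375 cells (Homo sapiens) for activation, with a stated time of 3 days (a lower number here means that less compound is needed, a higher number that more compound is needed for the effect), and show how much compound is needed for the effect. Compound 3 (11000 nM) stands level, within the usual scatter, with compound 1 (7000 nM). Set against compound 3 (11000 nM), compound 2 (3000 nM) needs clearly less compound, a gap beyond the scatter.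

Next comes compound 4 `O=C(Nc1ccc(-c2cccs2)cc1)C1CCCN(Cc2ccc(F)c(F)c2)C1`, which differs from compound 3 in one place: thiophen-2-yl in place of pyridin-2-yl on an aromatic carbon.

Among the measured compounds shown here, no measured pair isolates this swap. For the measured compounds named here, the one measured step, a 2.3-fold lower number from compound 1 to compound 2 (0.37 log units; beyond the scatter), is modest and lies elsewhere in the molecule, as 3,4-dichlorophenyl in place of 2-fluorophenyl. It offers only a rough sense of how far a single change moves the number here, and no direction for this swap. No step beyond the scatter is therefore expected in this assay, in either direction. The estimated step runs a 1.6-fold lower number from compound 3 to compound 4 (0.20 log units; within the scatter), a small one that the next measurement may well overturn. For compound 4 the estimate is 7000 nM, with an expected range from 3000 nM to 15000 nM, and the measurement will show where it really falls.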

Compound 4, half-maximal effective concentration: 530 nM
Estimate against measurement, compound 4: 13-fold (1.12 log units) above, outside the stated range (below it).
By their numbers in this assay, from the lowest: compound 4; then compound 2; then compounds 1 and 3 (each within the scatter of the next).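

Placing thiophen-2-yl in place of pyridin-2-yl, on an aromatic carbon para to a large group, gives a 21-fold lower number from compound 3 to compound 4 (1.32 log units; beyond the scatter) in this assay, so this position can move the number far more than the earlier compounds suggested, where the only measured step was the modest 2.3-fold lower number from compound 1 to compound 2 (0.37 log units; beyond the scatter). The exchange replaces a six-membered aromatic ring holding nitrogen with a five-membered aromatic ring holding sulfur, while the counts of hydrogen-bond donors and acceptors stay the same, so those counts do not separate the two groups. Ring size and the identity of the hetero atom change together in this single pair, and no available evidence explains the large step.

The compounds shown leave open which of those two changes matters, and a furan-2-yl group, a five-membered aromatic ring holding oxygen, at the same position would help to separate them. They also leave open whether thiophen-2-yl would give a similar step when the rest of the molecule changes, for instance with the 3,4-dichlorophenyl group of compound 2 in place of the group carried by compound 4.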